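This account rests on a few compounds, and the source may have more. Where it says the series, first, only, none or still open, it means among the compounds named here.

Compound 1 `CCCCCCCCn1cc(/C=C/C(=O)c2ccc(NC(=O)CN3CCN(C(=O)OC(C)(C)C)CC3)cc2)nn1` gives 98400 nM in a functional assay on MCF7 cells (Homo sapiens) for inhibition, read by MTT assay; a higher number here means a weaker inhibitor, a lower number a stronger inhibitor.
Compound 2 `COc1ccccc1N1CCN(CC(=O)Nc2ccc(C(=O)/C=C/c3cn(Cc4ccc(Br)cc4)nn3)cc2)CC1` gives 36800 nM in this assay.
Compound 3 `CCCCCCCCCCn1cc(/C=C/C(=O)c2ccc(NC(=O)CN3CCN(C(=O)OC(C)(C)C)CC3)cc2)nn1` gives 40000 nM in this assay.

Among these three numbers compound 3 stands second highest. Its number and that of compound 2 lie within the scatter of each other, so nothing separates them. Within the data shown here, the only measured step is a 2.5-fold lower number from compound 1 to compound 3 (0.39 log units; beyond the scatter), a lengthening of the saturated chain that sits on the aromatic nitrogen.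

Compound 4 `CCCCCCCCCCn1cc(/C=C/C(=O)c2ccc(NC(=O)CN3CCN(c4ccccc4OC)CC3)cc2)nn1` is compound 3 with one change: 2-methoxyphenyl in place of tert-butoxycarbonyl on an amine nitrogen in a ring. Among the measured compounds shown here, no measured step covers this exchange directly. Compound 2 carries the same 2-methoxyphenyl on the ring nitrogen, but it also differs from compound 3 at the aromatic nitrogen, so it offers only a hint; what it shows is that a compound bearing the 2-methoxyphenyl can sit at a number close to that of compound 3. The step in this assay between compound 1 and compound 3 concerns a different place and says nothing about the ring nitrogen. On this footing no step beyond the scatter is expected for compound 4, which would mean a 1.1-fold lower number from compound 3 to compound 4 (0.06 log units; within the scatter). The estimate for compound 4 in this assay is therefore 35000 nM, expected to fall between 12000 nM and 100000 nM.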

Compound 4, half-maximal inhibitory concentration: 44800 nM
The estimate for compound 4 lay 1.3-fold (0.11 log units) below the measured number, and the stated range covers the measured number.
By their numbers in this assay, from the lowest: compounds 2, 3 and 4 (each within the scatter of the next); then compound 1.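

Replacing tert-butoxycarbonyl with 2-methoxyphenyl on the amine nitrogen in the ring gives a 1.1-fold higher number from compound 3 to compound 4 (0.05 log units; within the scatter) in this assay and shows that, in this pair, a group with an aromatic ring of carbon only and a group with no ring cannot be told apart at this position. A second exchange, nonyl in place of 4-bromophenyl on the saturated chain carbon bound to an aromatic nitrogen, gives a 1.2-fold higher number from compound 2 to compound 4 (0.09 log units; within the scatter) and shows that, with 2-methoxyphenyl on the ring nitrogen, this exchange also leaves the number within the scatter. Nothing independent of these numbers bears on the two results, so no reason for them can be offered.

As far as these compounds go, both groups compared on the ring nitrogen are large, so it remains open whether a much smaller one, such as a methyl group or the hydrogen of a free amine, would give a different number. From the compounds shown here alone, it also remains open whether 2-methoxyphenyl would read the same way on the chain of compound 1, which carries the shorter of the two saturated chains joined by the measured step.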